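The source may hold more compounds than are shown below. What is called first, only, known or untested is meant among the compounds shown, and "the series" means these compounds.

Working notes on the series. Compound 1 `Cc1nsc2c1nc(SCc1ccccc1)n2[C@H]1C[C@H](O)[C@@H](CO)O1` is inactive in a functional assay on HFF cells (Homo sapiens) for inhibition; a lower number here means a stronger inhibitor, a higher number a weaker inhibitor; in this assay compound 1 gives only a limit, > 100000 nM. Compound 2 `OC[C@H]1O[C@@H](n2c(SCc3ccccc3)nc3cnsc32)C[C@@H]1O` likewise gives only a limit, > 100000 nM. The change between them is hydrogen in place of methyl on an aromatic carbon, and the step that the two limits leave unreadable from compound 1 to compound 2 cannot be read because of the limit of > 100000 nM in this assay, at which 2 of the 3 values shown sit. Compound 3 `CSc1nc2snc(C)c2n1[C@H]1C[C@H](O)[C@@H](CO)O1` carries a different core; how it differs from compound 1 is not broken down here. In this assay, within the data shown here, compound 3 gives 32000 nM, the only number in the set. Compound 4 `CSc1nc2sncc2n1[C@H]1C[C@H](O)[C@@H](CO)O1` is not yet measured and differs from compound 3 by hydrogen in place of methyl on an aromatic carbon, the same kind of change as from compound 1 to compound 2. Since the earlier step sits between two limits, it gives no size to lean on; compound 4 is expected near compound 3, with a step of a 1.6-fold higher number from compound 3 to compound 4 (0.19 log units; within the scatter) estimated, and a value of about 50000 nM, between 15000 nM and 160000 nM, is expected.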

Compound 4, half-maximal inhibitory concentration: 15000 nM
Compound 4: middle estimate off by 3.3-fold (0.52 log units), on the high side; measured number inside the range.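

On the core of compound 3, hydrogen in place of methyl on an aromatic carbon gives a 2.1-fold lower number from compound 3 to compound 4 (0.33 log units; beyond the scatter) in this assay. The same change from compound 1 to compound 2 cannot be read, and the reason is this: the limit of > 100000 nM in this assay, at which 2 of the 4 values shown sit. Whether the step carries from one core to the other is therefore not shown, since only one readable pair stands in the series and a single pair makes no pattern.

Left open is how the number in this assay would respond to an ethyl group, a trifluoromethyl group, an amine or a carboxylic acid on that same aromatic carbon. Also open, going by these compounds, is whether any such group would give a step of similar size on both cores.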